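The compounds below may be only part of what the source reports. "The series", "measured", "known", "first", "only" and "open" are said of these compounds alone.

Compound 2 `COc1ccc(C(OCc2ccc(C)cc2)c2cccc3ccccc23)c(OC)c1OC` is one of two compounds tested in a functional assay on A549 cells (Homo sapiens) for inhibition, read by sulforhodamine B assay, with a stated time of 48 h; on this read-out higher numbers stand for weaker inhibition and lower numbers for stronger inhibition. In this assay compound 2 gives 15700 nM, and compound 1 `COc1ccc(C(c2ccc(OC(C)CN(C)C)cc2)c2cccc3ccccc23)c(OC)c1OC` gives 11400 nM; the two numbers lie within the scatter of each other, so neither can be set apart from the other on this assay. Compound 3 `COc1ccc(C(c2ccc(OCC(=O)O)cc2)c2cccc3ccccc23)c(OC)c1OC` has not yet been measured. It differs from compound 2 in one place: 4-(carboxymethoxy)phenyl in place of (4-methylbenzyl)oxy on a saturated chain carbon bound to two aromatic carbons. Going by the values given here, no step between measured compounds covers this change, so its size is unknown. The expectation is for a step of modest size toward a higher number, a 1.6-fold higher number from compound 2 to compound 3 (0.20 log units; within the scatter), because compound 1 gives 11400 nM and does not suggest a strong inhibitor in this series, and compound 3, like compound 1, carries an aromatic ring on the saturated chain carbon bound to two aromatic carbons. Compound 3 is therefore estimated at 25000 nM, with a likely range from 8000 nM to 80000 nM.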

Compound 3, half-maximal inhibitory concentration: 16400 nM
Estimate against measurement, compound 3: 1.5-fold (0.18 log units) above; measured number inside the range.
By their numbers in this assay, from the lowest: compounds 1, 2 and 3 (each within the scatter of the next).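

In this assay, 4-(carboxymethoxy)phenyl in place of (4-methylbenzyl)oxy on a saturated chain carbon bound to two aromatic carbons amounts to a 1.0-fold higher number from compound 2 to compound 3 (0.02 log units; within the scatter) and so leaves the read-out unresolved from the earlier value, showing that this position accepts either group without a measurable difference here. Carboxymethyl in place of 1-((dimethylamino)methyl)ethyl on an oxygen on an aromatic ring amounts to a 1.4-fold higher number from compound 1 to compound 3 (0.16 log units; within the scatter) and likewise separates neither compound, so a carboxylic acid and a dimethylamino group at the end of that chain cannot be told apart on this read-out. Nothing measured here offers an explanation for these results.

As far as these compounds go, whether any change at either place can move the number beyond the scatter remains open. A hydroxyl on the saturated chain carbon, or a primary amide or longer chain in place of carboxymethyl, could test this.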